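A few compounds are considered here, and "the series" means these few. Any claim that something is new, unique, unknown or untested is made for them only; others in the source may bear on it.

Measured compounds:
- compound 1, `COc1ccc2nc(C(F)(F)F)cc(OCC(=O)Nc3cc(C)cc(C)c3)c2c1`: 15000 nM
- compound 2, `COc1ccc2nc(C)cc(OCC(=O)Nc3cc(C)ccc3C)c2c1`: 45500 nM

Of the compounds shown here, two have been measured in a physicochemical assay for solubility, in phosphate buffer, measured as kinetic solubility, with a stated time of 1 h, at pH 7.4; a higher number here means a more soluble compound, a lower number a less soluble compound. Compound 1 gives 15000 nM in this assay, and compound 2 gives 45500 nM. Of the two numbers, compound 2 stands highest; the gap down to compound 1 lies beyond the usual scatter of this assay, so compound 2 is the more soluble of the pair as far as these two numbers go. Within the data shown here, no single-change step between the two measured compounds is available, so only the two values themselves can be compared.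

Compound 3, `COc1ccc2nc(C)cc(OCC(=O)NNC(=O)c3ccncc3)c2c1`, has not yet been measured in this assay. It differs from compound 2 in one place, (((pyridin-4-yl)carbonyl)amino in place of 2,5-dimethylphenyl on an amide-type nitrogen), so that the amide-type nitrogen now carries ((pyridin-4-yl)carbonyl)amino where compound 2 carries 2,5-dimethylphenyl.

On this basis the step from compound 2 to compound 3 in this assay is expected to be upward, of the size a 2.6-fold higher number from compound 2 to compound 3 (0.42 log units; beyond the scatter), rather than flat within the scatter. For compound 3 the estimated solubility in this assay is 120000 nM, with a range from 40000 nM to 350000 nM.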

Compound 3, solubility: >= 375000 nM
Compound 3 ended at the assay's limit; the forecaster's own chance of this, stated with the estimate: 15%; middle value at least 3.1-fold (0.49 log units) from the limit.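

In this assay compound 3 gives >= 375000 nM, and this value is a limit of the assay, not a number. Among these compounds, on the amide-type nitrogen whose other neighbour is the carbonyl carbon, putting ((pyridin-4-yl)carbonyl)amino in place of 2,5-dimethylphenyl gives an at least 8.2-fold higher number from compound 2 to compound 3 (0.91 log units; beyond the scatter), the first step in this set that can be read for a change in one place, and it lies beyond the scatter. The earlier compounds could offer only two values that differ in more than one place, whereas this pair ties a change in this assay to this one position, though the step gives only a lower bound on its size: the limit of >= 375000 nM in this assay, at which 1 of the 3 values shown sits.

The compounds shown leave open which part of the entering group goes with the step, as the pyridin-4-yl ring, the carbonyl and the added nitrogen all enter together in a single change. They also leave open how a benzoylamino group, which keeps the carbonyl and the added nitrogen but has a ring of carbon only, or a morpholine or a carboxylic acid on the same side chain, would read in this assay.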